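This account rests on a few compounds, and the source may have more. Where it says the series, first, only, none or still open, it means among the compounds named here.

Measured so far in a functional assay on NCI-H1975 cells (Homo sapiens) for antiproliferative activity; on this read-out higher numbers stand for weaker inhibition and lower numbers for stronger inhibition:
- compound 1 `CC(=O)N1CCCc2c(C)c3c(n2-c2ccc(C(N)=O)c(c2)N[C@@H](C)[C@@H]1C)CC(C)(C)CC3=O`: 20 nM
- compound 2 `CC(=O)N1CCc2c(C)c3c(n2-c2ccc(C(N)=O)c(c2)N[C@@H](C)[C@H](C)C1)CC(C)(C)CC3=O`: 15 nM
- compound 3 `Cc1c2c(n3c1CCCN(C(=O)CN)[C@@H](C)[C@H](C)Nc1cc-3ccc1C(N)=O)CC(C)(C)CC2=O`: 380 nM

Compound 2, at 15 nM, lies within the usual scatter of compound 1, at 20 nM, so these two cannot be ranked. Both sit well under compound 3, at 380 nM.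

The unmeasured compound 4 `Cc1c2c(n3c1CCN(C(=O)CN)C[C@@H](C)[C@H](C)Nc1cc-3ccc1C(N)=O)CC(C)(C)CC2=O` differs from compound 2 in one place: amino in place of hydrogen on a saturated chain carbon bound to a carbonyl carbon. Put simply, this is amino in place of hydrogen on a saturated chain carbon bound to a carbonyl carbon, which turns acetyl to (aminomethyl)carbonyl.

Among the compounds with values here, only one measured step makes this same swap, and it is large: a 19-fold higher number from compound 1 to compound 3 (1.28 log units; beyond the scatter). That step starts from compound 1, whose core is not identical to that of compound 2, so it is a single precedent and not an established rule. Even so, it gives no reason to expect a small change. In this assay, a large step towards a higher number, meaning weaker inhibition, is expected. The expected change is a 19-fold higher number from compound 2 to compound 4 (1.27 log units; beyond the scatter). For compound 4 the estimated value is 280 nM, with an expected range from 90 nM to 800 nM.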

Compound 4, half-maximal inhibitory concentration: 190 nM
Compound 4: the middle estimate sits 1.5-fold (0.17 log units) above what was measured; the range from low to high includes it.
By their numbers in this assay, from the lowest: compounds 2 and 1 (each within the scatter of the next); then compounds 4 and 3 (each within the scatter of the next).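

In this assay, turning acetyl to (aminomethyl)carbonyl gives a 13-fold higher number from compound 2 to compound 4 (1.10 log units; beyond the scatter), so this change is now seen to weaken inhibition on a second core as well as on the core of compound 1. Until now the change rested on a single step, which might have been a peculiarity of that one core, but the two steps now point the same way and are close in size: the same change on two cores in this assay, a 19-fold higher number (1.28 log units; beyond the scatter) from compound 1 to compound 3 and a 13-fold higher number (1.10 log units; beyond the scatter) from compound 2 to compound 4, 1.5-fold (0.18 log units) apart, within the scatter of two such steps On the two cores shown, then, the saturated chain carbon bound to the carbonyl carbon tolerates hydrogen far better than amino, and no compound shown goes against this.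

The compounds shown carry only hydrogen or amino at this place, so they leave open whether the weaker inhibition belongs to the amino group itself or would follow any other group put there. A hydroxyl, a dimethylamino group or a carboxylic acid at the same carbon, or a longer chain such as aminoethyl in place of aminomethyl, would help to tell these two readings apart.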